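Trimming One Trifluoromethyl from a Thiourea Antiproliferative

The source may report more compounds than this note shows. Statements on the series, on what has been measured and on what is new or still open speak of the compounds shown alone.

Three thioureas built on a shared core were tested in a functional assay on MDA-MB-231 cells (Homo sapiens) for antiproliferative activity, read by MTT assay; a lower number here means a stronger inhibitor, a higher number a weaker inhibitor. Compound 1 `CNC(=O)c1ccc(Oc2cccc(NC(=S)Nc3ccc(F)cc3)c2)nc1` gives 21700 nM, compound 2 `CNC(=O)c1ccc(Oc2cccc(NC(=S)Nc3ccc(F)c(C(F)(F)F)c3)c2)nc1` gives 13300 nM, and compound 3 `CNC(=O)c1ccc(Oc2cccc(NC(=S)Nc3cc(C(F)(F)F)cc(C(F)(F)F)c3)c2)nc1` gives 2670 nM, the strongest of the three. The change hydrogen in place of trifluoromethyl on an aromatic carbon produced a 1.6-fold higher number from compound 2 to compound 1 (0.21 log units; within the scatter). How the core of compound 3 differs from that of compound 2 is not broken down here. Compound 4 `CNC(=O)c1ccc(Oc2cccc(NC(=S)Nc3cccc(C(F)(F)F)c3)c2)nc1` carries the same kind of change as hydrogen in place of trifluoromethyl on an aromatic carbon; around the place, the earlier change sat ortho to a fluoro group, whereas this one sits meta to a trifluoromethyl group. One guide for the expectation is a 1.6-fold higher number from compound 2 to compound 1 (0.21 log units; within the scatter). The other is the gap between the values of compound 2 and compound 3 in this assay. Resting on these, compound 4 is expected to show a 2.2-fold higher number from compound 3 to compound 4 (0.35 log units; beyond the scatter). Compound 4 is estimated at 6000 nM, within 2500 nM to 15000 nM.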

Compound 4, half-maximal inhibitory concentration: 38100 nM
Compound 4: the middle estimate sits 6.4-fold (0.80 log units) below what was measured, and the stated range ends below it.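

Hydrogen in place of trifluoromethyl did not carry over as a fixed step in this assay between the two cores: the same change on two cores in this assay, a 1.6-fold higher number (0.21 log units; within the scatter) from compound 2 to compound 1 and a 14-fold higher number (1.15 log units; beyond the scatter) from compound 3 to compound 4, 8.7-fold (0.94 log units) apart, beyond the scatter of two such steps.

The new steps are a 14-fold higher number from compound 3 to compound 4 (1.15 log units; beyond the scatter) for that change, a 2.9-fold higher number from compound 2 to compound 4 (0.46 log units; beyond the scatter) for hydrogen in place of fluoro, and a 1.8-fold higher number from compound 1 to compound 4 (0.24 log units; within the scatter) for 3-(trifluoromethyl)phenyl in place of 4-fluorophenyl, this last within the scatter. Two pairs show that one core's step cannot be read across to the other, but not why they part, nor what a further core would give.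

Still open, from the compounds shown here alone, is how a chlorine atom, a methyl group or a nitrile would fare where the trifluoromethyl left compound 3.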